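This account rests on a few compounds, and the source may have more. Where it says the series, first, only, none or still open, it means among the compounds named here.

Of the compounds shown here, three have been measured in a functional assay on PC-3 cells (Homo sapiens) for inhibition, read by MTT assay, with a stated time of 48 h, tested at 10 uM; a lower number here means less inhibition of growth, a higher number more inhibition of growth at the concentration tested. Compound 1 `Cc1cc(=O)c2c(O)c(CN3CC(O)CC3C(=O)O)c(O)c([C@H]3CCN(C)C[C@H]3O)c2o1` gives 0%, and compound 2 `CCCCCCCCCC/C=C/c1c(C)oc2c([C@H]3CCN(C)C[C@H]3O)c(O)cc(O)c2c1=O` gives 0%. Compound 3 `CN1CC[C@H](c2c(O)cc(O)c3c(=O)cc(/C=C/c4ccccc4)oc23)[C@H](O)C1` gives 10%, which lies within the scatter of both others, so the three cannot be told apart. Compound 4 `CN1CC[C@H](c2c(O)cc(O)c3c(=O)cc(/C=C/c4c(F)c(F)c(F)c(F)c4F)oc23)[C@H](O)C1` differs from compound 3 in one place: 2,3,4,5,6-pentafluorophenyl in place of phenyl on a double-bonded chain carbon bound to a double-bonded chain carbon. Here 2,3,4,5,6-pentafluorophenyl stands in place of phenyl on a double-bonded chain carbon bound to a double-bonded chain carbon. For the measured compounds named here, no measured pair differs in just one place, so the data offer no direct guide, and no step beyond the scatter is expected in this assay. The estimated change is a number 2 percentage points higher from compound 3 to compound 4 (within the scatter). The expected value for compound 4 is 12%, within an estimated range of 0% to 35%.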

Compound 4, percent growth inhibition at one concentration: 82%
Beside the measured number, compound 4's estimate is 70 percentage points below it, outside the stated range (above it).
By their numbers in this assay, from the lowest: compounds 1, 2 and 3 (each within the scatter of the next); then compound 4.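

Placing 2,3,4,5,6-pentafluorophenyl in place of phenyl on a double-bonded chain carbon bound to a double-bonded chain carbon gives a number 72 percentage points higher from compound 3 to compound 4 (beyond the scatter) in this assay, the first step here beyond the scatter. So this place on the chain can separate active from nearly inactive compounds, which the earlier compounds, all within the scatter of one another, could not show. Nothing available explains the jump. Still open, on these data alone, is whether a phenyl carrying a single fluorine, or a pentachlorophenyl, would behave like compound 4. As far as these compounds go, it is also open whether this step would hold on the other chains seen in compound 1 and compound 2.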